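The source may report more compounds than this note shows. Statements on the series, on what has been measured and on what is new or still open speak of the compounds shown alone.

Measured so far:
compound 1 `CC(=O)C(=O)Nc1ccc2nc(NC(=O)c3cc4ccccc4[nH]3)sc2c1` — > 50000 nM
compound 2 `CCOC(=O)C(=O)Nc1ccc2nc(NC(=O)c3ncccn3)sc2c1` — > 50000 nM

In a functional assay on SK-BR-3 cells (Homo sapiens) for antiproliferative activity (a lower number here means that less compound is needed, a higher number that more compound is needed for the effect), compound 2 gives > 50000 nM, which is a limit of the assay rather than a number. Compound 1 likewise gives > 50000 nM, also a limit; (the limit of > 50000 nM in this assay, at which 2 of the 2 values shown sit). Among the measured compounds shown here, no step between measured compounds can be counted here. Compound 3 `CCOC(=O)C(=O)Nc1ccc2nc(NC(=O)c3cc4ccccc4[nH]3)sc2c1` differs from compound 2 by 1H-indol-2-yl in place of pyrimidin-2-yl on a carbonyl carbon. Compound 1 already carries the same 1H-indol-2-yl group on its carbonyl carbon and sits at the limit. The step of a number no higher from compound 2 to compound 3 (the limit leaves the size open) is expected to be none beyond the scatter. Compound 3 is expected to give 50000 nM, within 20000 nM to 150000 nM, most likely again only as a limit.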

Compound 3, half-maximal effective concentration: 5410 nM
Estimate against measurement, compound 3: 9.2-fold (0.97 log units) above; the whole stated range lies above it.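

In this assay, 1H-indol-2-yl in place of pyrimidin-2-yl on a carbonyl carbon gives an at least 9.2-fold lower number from compound 2 to compound 3 (0.96 log units; beyond the scatter), so this group matters when ethoxy is present. Ethoxy in place of methyl on a carbonyl carbon gives an at least 9.2-fold lower number from compound 1 to compound 3 (0.96 log units; beyond the scatter), so 1H-indol-2-yl alone does not lift a compound off the limit. Neither step has a fixed size, since each starts from a limit: the limit of > 50000 nM in this assay, at which 2 of the 3 values shown sit.

Going by these compounds, whether a longer chain such as propoxy would lower the number further stays open. So does whether a plain phenyl group could stand in for 1H-indol-2-yl.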